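A few compounds are considered here, and "the series" means these few. Any claim that something is new, unique, unknown or untested is made for them only; others in the source may bear on it.

In a functional assay on HT-29 cells (Homo sapiens) for antiproliferative activity, read by MTT assay, with a stated time of 24 h (on this read-out lower numbers stand for stronger inhibition and higher numbers for weaker inhibition), compound 1 `COc1ccc(C(=O)/C=C/c2ccc([N+](=O)[O-])cc2)c2c1C=CC(C)(C)O2` gives 3730 nM and compound 2 `COc1ccc(C(=O)/C=C/c2ccccn2)c2c1C=CC(C)(C)O2` gives 2120 nM. For the measured compounds named here, compound 2 holds the lower of only two numbers, but the gap is too small to separate the pair. The next structure, compound 3 `COc1ccc(C(=O)/C=C/c2ccccc2Cl)c2c1C=CC(C)(C)O2`, changes the same place on the chain: 2-chlorophenyl in place of pyridin-2-yl on a double-bonded chain carbon bound to a double-bonded chain carbon. In words, this puts 2-chlorophenyl in place of pyridin-2-yl on a double-bonded chain carbon bound to a double-bonded chain carbon. Going by the values given here, only one measured step bears on this place, a 1.8-fold lower number from compound 1 to compound 2 (0.25 log units; within the scatter), so exchanging the ring group there has so far stayed within the scatter. Among the compounds with values here, no measured compound carries chlorine, so this single step is thin evidence. The expected change is a 1.2-fold higher number from compound 2 to compound 3 (0.07 log units; within the scatter), and no shift beyond the scatter is expected in this assay. For compound 3 the estimated value is 2500 nM, with an expected range from 1000 nM to 6000 nM.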

Compound 3, half-maximal inhibitory concentration: > 10000 nM
Compound 3 ended at the assay's limit; the forecaster's own chance of this, stated with the estimate: 3%; at least 4.0-fold (0.60 log units) between middle value and limit.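

In this assay compound 3 stands at > 10000 nM, which is a limit of the assay and not a number. For the compounds shown here, this place on the chain turns out not to be indifferent to the ring group it carries, since the one earlier exchange stayed within the scatter, while 2-chlorophenyl gives an at least 4.7-fold higher number from compound 2 to compound 3 (0.67 log units; beyond the scatter) and an at least 2.6-fold higher number from compound 1 to compound 3 (0.42 log units; beyond the scatter). Both steps are only minimum sizes, and the real loss of activity could be larger, because the reading stops at the limit: the limit of > 10000 nM in this assay, at which 1 of the 3 values shown sits.

The compounds shown leave open whether this loss belongs to the chlorine itself or to the 2-chlorophenyl group as a whole, a question that a plain phenyl ring at this place would help to answer. They also leave open how a ring carrying a methyl group, a methoxy group or an amine would behave here.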